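A few compounds are considered here, and "the series" means these few. Any claim that something is new, unique, unknown or untested is made for them only; others in the source may bear on it.

Compound 3 `COc1nc2ccc(Br)cc2cc1C(c1ccccc1)n1cc(CO)nn1` carries a hydroxymethyl group on its five-membered ring. In an ADME assay on PANC-1 cells (Homo sapiens) for cytotoxicity, read by sulforhodamine B assay, with a stated time of 48 h, tested at 10 uM (a lower number here means less inhibition, a higher number more inhibition at the concentration tested (going by the name of the read-out)), compound 3 gives 15%, the middle of three numbers that all sit within the usual scatter of one another: compound 2 `CCCCCCCc1cn(C(c2ccccc2)c2cc3cc(Br)ccc3nc2OC)nn1` gives 16.6% and compound 1 `COc1nc2ccc(Br)cc2cc1C(c1ccccc1)n1cc(-c2ccc(Br)cc2)nn1` gives 10.4%. Compound 4 `COc1nc2ccc(Br)cc2cc1C(c1ccccc1)n1cc(-c2ccccc2C(F)(F)F)nn1` differs from compound 3 by 2-(trifluoromethyl)phenyl in place of hydroxymethyl on an aromatic carbon. The step that bears on this swap runs the other way, exchanging an aryl group for hydroxymethyl, a number 4.6 percentage points higher from compound 1 to compound 3 (within the scatter), and the swap of the same aryl group for a heptyl chain, a number 6.2 percentage points higher from compound 1 to compound 2 (within the scatter), likewise stayed within the scatter. A step of a number 4 percentage points lower from compound 3 to compound 4 (within the scatter) is therefore expected, nothing beyond the scatter. Compound 4 is estimated at 11%, with a likely range from 3% to 20%.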

Compound 4, a percentage reported as inhibition, at one concentration (the size of the read-out at that concentration, not a potency): 11.4%
Compound 4: middle estimate off by 0.4 percentage points, on the low side; the range from low to high includes it.
By their numbers in this assay, from the lowest: compounds 1, 4, 3 and 2 (each within the scatter of the next).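

In this assay, 2-(trifluoromethyl)phenyl at this carbon of the five-membered ring gives a number 3.6 percentage points lower from compound 3 to compound 4 (within the scatter) and, set against the heptyl chain, a number 5.2 percentage points lower from compound 2 to compound 4 (within the scatter), so a third kind of group still does not separate from hydroxymethyl or heptyl. Exchanging one substituted phenyl for another gives a number 1 percentage points higher from compound 1 to compound 4 (within the scatter), so the two aryl groups cannot be told apart here. No measurement on hand explains these numbers. Going by these compounds, whether an amine or a carboxylic acid at this carbon would move the number beyond the scatter remains open.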